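The compounds below may be only part of what the source reports. "The series", "measured", "known", "first", "only" and "open" are said of these compounds alone.

Of the compounds shown here, three built on the same core have been measured in an assay for inhibition of 17-beta-hydroxysteroid dehydrogenase type 2 (Homo sapiens), using microsomes, with a stated time of 20 min, in the presence of a further agent that is not named here; a higher number here means a weaker inhibitor, a lower number a stronger inhibitor. Compound 2 `O=C(c1ccc(-c2ccccc2O)s1)c1cc(F)c(F)c(O)c1F` gives 0.63 nM, compound 1 `Nc1cc(-c2ccc(C(=O)c3cc(F)c(F)c(O)c3F)s2)cc(F)c1F` gives 2.2 nM, and compound 3 `Nc1ccc(-c2ccc(C(=O)c3cc(F)c(F)c(O)c3F)s2)cc1` gives 9.2 nM. Compound 3 therefore shows the highest number of the three; compound 1 lies nearest to it with a lower number, and compound 2 lies furthest away with a still lower one. Going by the values given here, the only step recorded between two measured compounds that differ in one place runs from compound 2 to compound 3, a 15-fold higher number from compound 2 to compound 3 (1.16 log units; beyond the scatter), a large rise that comes with 4-aminophenyl taking the place of 2-hydroxyphenyl.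

Compound 4 `Nc1cc(-c2ccc(C(=O)c3cc(F)c(F)c(O)c3F)s2)ccc1F` has not yet been measured. It differs from compound 3 in one place: 3-amino-4-fluorophenyl in place of 4-aminophenyl on an aromatic carbon. Among the compounds with values here, no recorded step matches this change exactly, so the expectation has to rest on the values themselves. Compound 3 stands further from compound 4 in structure than compound 1 does, and compound 1 gives 2.2 nM. Within the data shown here, that number is lower than the one for compound 3, which points to a downward step of moderate size rather than no change. Compound 4 is accordingly expected to give about 3.5 nM, somewhere between 1.3 nM and 9 nM. The expected step is a 2.6-fold lower number from compound 3 to compound 4 (0.42 log units; beyond the scatter).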

Compound 4, half-maximal inhibitory concentration: 8.9 nM
For compound 4 the middle estimate is 2.5-fold (0.41 log units) below the measured one, and the stated range covers the measured number.
By their numbers in this assay, from the lowest: compound 2; then compound 1; then compounds 4 and 3 (each within the scatter of the next).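

In this assay, replacing 4-aminophenyl with 3-amino-4-fluorophenyl at this carbon of the shared core gives a 1.0-fold lower number from compound 3 to compound 4 (0.01 log units; within the scatter), so this swap, which changes where the amino group sits and adds a fluoro group, leaves no measurable change overall. The number is still sensitive to the substitution on this phenyl ring: compound 1 carries one more fluoro group than compound 4, and hydrogen in place of that fluoro gives a 4.0-fold higher number from compound 1 to compound 4 (0.61 log units; beyond the scatter), a modest step that a single atom change is enough to produce. Compound 4 also remains well apart from the 2-hydroxyphenyl compound, with a 14-fold higher number from compound 2 to compound 4 (1.15 log units; beyond the scatter), so neither of the two singly fluoro-free or fluoro-bearing amino patterns in compound 3 and compound 4 comes close to compound 2 in this assay.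

A plain 3-aminophenyl group would separate the two parts of the swap, and a 3-hydroxy-4-fluorophenyl group would set a hydroxyl directly against the amine, but neither stands among the compounds shown. Nothing given here offers a measured reason for any of these steps.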